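Clearance from compound 2 to compound 4

A few compounds are considered here, and "the series" means these few. Any claim that something is new, unique, unknown or untested is made for them only; others in the source may bear on it.

Values measured in an ADME assay on liver (Mesocricetus auratus) for metabolic stability, using microsomes; a higher number here means faster removal of the compound, a lower number slower removal:
- compound 1 `O=C(NCc1ccccc1)Nc1[nH]nc(-c2ccccn2)c1Cl`: > 400 mL.min-1.g-1 (a limit of the assay, not a number)
- compound 2 `N#Cc1ccc(OC2CCN(C(=O)Nc3cc(-c4ccccn4)n[nH]3)CC2)cc1`: 30.8 mL.min-1.g-1
- compound 3 `O=C(Nc1cc(-c2ccccn2)n[nH]1)N1CCN(c2ccc(F)cc2)CC1`: 46.5 mL.min-1.g-1

Compound 2 (30.8 mL.min-1.g-1) and compound 3 (46.5 mL.min-1.g-1) lie within the usual scatter of each other, so these two cannot be told apart. Compound 1 is reported only as a limit (> 400 mL.min-1.g-1).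

The next compound to be tested is compound 4 `O=C(Nc1cc(-c2ccccn2)n[nH]1)N1CCC(c2ccccc2)CC1`. Compared with compound 2, it carries phenyl in place of 4-cyanophenoxy on a saturated ring carbon. Among the measured compounds shown here, no two measured compounds differ in just one place, so this change has no direct precedent here. The nearest guide is compound 3 (46.5 mL.min-1.g-1), which also lacks the nitrile and stays within the scatter of compound 2. In this assay a small rise, within the usual scatter, is therefore expected (a 1.8-fold higher number from compound 2 to compound 4 (0.25 log units; within the scatter)). For compound 4 the estimated value is 55 mL.min-1.g-1 (expected range 22 mL.min-1.g-1 to 140 mL.min-1.g-1).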

Compound 4, intrinsic clearance in microsomes: 216 mL.min-1.g-1
For compound 4 the middle estimate is 3.9-fold (0.59 log units) below the measured one, outside the stated range (above it).
By their numbers in this assay, from the lowest: compounds 2 and 3 (each within the scatter of the next); then compound 4. At a limit, above all of these: compound 1.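

Replacing 4-cyanophenoxy with phenyl on a saturated ring carbon gives a 7.0-fold higher number from compound 2 to compound 4 (0.85 log units; beyond the scatter) in this assay. Among the compounds shown here, this is the first change in a single place to be measured here, and it shows that the group at this position can strongly affect how fast the compound is removed, with phenyl giving the faster removal in this pair. Compound 1 stays outside this comparison, as its reading is a limit of the assay and not a number: the limit of > 400 mL.min-1.g-1 in this assay, at which 1 of the 4 values shown sits.

The change removes the oxygen link and the nitrile together, so this pair cannot show which loss goes with the rise; unsubstituted phenoxy or 4-cyanophenyl would separate the two. On these data alone, whether an amine or a carboxylic acid at this position would give slower removal also remains open.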